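The compounds below may be only part of what the source reports. "The series", "measured", "known", "first", "only" and "open" are said of these compounds alone.

Measured compounds:
compound 1 `Cc1ccc(-c2nc(S)[nH]c(=O)n2)cc1` — 6.58%
compound 2 `N#Cc1cccc(CSc2nc(SCc3ccccc3)nc(=O)[nH]2)c1` — "not determined" (no result reported)

In an assay for inhibition of Pro-cathepsin H (Homo sapiens), read by fluorescence, tested at 50 uM (a lower number here means less inhibition, a higher number more inhibition at the concentration tested (going by the name of the read-out)), compound 1 gives 6.58%, a small read-out. On these data alone, compound 2 stands on no number here: nothing was reported for it, so its position in this assay is unknown. Compound 3 `O=C(O)CSc1nc(SCc2ccccc2)nc(=O)[nH]1` differs from compound 2 by carboxy in place of 3-cyanophenyl on a saturated chain carbon bound to a sulfur. Within the data shown here, with no measured step anywhere in the set, no direction can be read for this change; in this assay a step of any size, or none beyond the scatter, is expected with equal weight. Going by the low read-out of compound 1 6.58% as the only number on the shared core, compound 3 is estimated at 10%, with an expected range of 0% to 32%.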

Compound 3, a percentage reported as inhibition, at one concentration (the size of the read-out at that concentration, not a potency): 6.89%
Compound 3: middle estimate off by 3.1 percentage points, on the high side, and the stated range covers the measured number.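

Among these compounds, no new step can be read from compound 3: compound 2, the one compound differing from it in one place, has no number. The compounds shown leave open whether carboxy in place of 3-cyanophenyl changes anything in this assay at all. No evidence bears on this result.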